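Working notes: amide-side change from compound 3 to compound 4

The source may report more compounds than this note shows. Statements on the series, on what has been measured and on what is new or still open speak of the compounds shown alone.

Three compounds of this series have results in an assay on HEK293 cells for displacement of a labelled ligand from C-C chemokine receptor type 4 (Homo sapiens); a higher number here means a weaker inhibitor, a lower number a stronger inhibitor: compound 1 `CN1CCCC(C(=O)NCCNc2nccc(OCc3ccc(Cl)cc3Cl)n2)C1`, compound 2 `O=C(c1cccnc1)N1CCN(c2nccc(OCc3ccc(Cl)cc3Cl)n2)CC1` and compound 3 `CN1CCCC(C(=O)N2CCN(c3nccc(NCc4ccc(Cl)cc4Cl)n3)CC2)C1`. In this assay compound 1 gives > 10000 nM, which is a limit of the assay. Compound 2 gives > 10000 nM, again a limit. Going by the values given here, compound 3 gives 700 nM, the only number among the three results; the other two sit at the limit of > 10000 nM in this assay, at which 2 of the 3 values shown sit. Compound 4 `O=C([C@H]1CCCN1)N1CCN(c2nccc(NCc3ccc(Cl)cc3Cl)n2)CC1` has not been measured. It differs from compound 3 in one place: pyrrolidin-2-yl in place of 1-methylpiperidin-3-yl on a carbonyl carbon. Both groups carry a ring nitrogen, and the entering group brings a hydrogen-bond donor that the leaving group lacks. Among the compounds with values here, no measured pair isolates this change, so the size of the step is open. The step of a 1.4-fold higher number from compound 3 to compound 4 (0.15 log units; within the scatter) is expected to be small, a modest loss at most and not clearly beyond the usual scatter. Compound 4 is therefore estimated at 1000 nM, with a range of 300 nM to 4000 nM.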

Compound 4, half-maximal inhibitory concentration: 60 nM
For compound 4 the middle estimate is 17-fold (1.22 log units) above the measured one, outside the stated range (below it).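

Working notes, continued: the position on the carbonyl carbon, whose other neighbour is an amide-type nitrogen in a ring, responds strongly in this assay, with a step of a 12-fold lower number from compound 3 to compound 4 (1.07 log units; beyond the scatter) on exchanging 1-methylpiperidin-3-yl for pyrrolidin-2-yl. Going by these compounds alone, no earlier pair isolated this position, so this is the first evidence that a change here alone can strengthen inhibition beyond the scatter. The change brings a five-membered ring, a hydrogen-bond donor and a defined stereocentre together, and nothing at hand identifies the cause of the step.

These three features remain inseparable in the compounds shown. Open comparisons are 1-methylpyrrolidin-2-yl, which keeps the five-membered ring but replaces the ring amine hydrogen with methyl, piperidin-2-yl, which keeps that hydrogen in a six-membered ring, and the opposite enantiomer of pyrrolidin-2-yl.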